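Swapping Cyano for Fluoro on the Benzyl Ring

This account rests on a few compounds, and the source may have more. Where it says the series, first, only, none or still open, it means among the compounds named here.

Compound 1, `COC(=O)c1ccc(NCc2cncn2Cc2cccc(C)c2)cc1-c1ccccc1`, gives > 10000 nM in a toxicity assay on NIH3T3 cells (Mus musculus) for cytotoxicity, read by resazurin assay (on this read-out higher numbers stand for an effect only at larger amounts of compound and lower numbers for an effect already at smaller amounts), which is a limit of the assay rather than a number.
Compound 2, `COC(=O)c1ccc(NCc2cncn2Cc2cccc(Cl)c2)cc1-c1ccccc1`, gives > 10000 nM in this assay, again a limit.
Compound 3, `COC(=O)c1ccc(NCc2cncn2Cc2cccc(C#N)c2)cc1-c1ccccc1`, gives > 10000 nM in this assay, again a limit.

Compound 3 therefore stands nowhere in particular on a scale of numbers: its value is only a limit, and the two companions share that same position because of the limit of > 10000 nM in this assay, at which 3 of the 3 values shown sit. For the measured compounds named here, no compound among the three can be called more or less toxic than another.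

Compound 4, `COC(=O)c1ccc(NCc2cncn2Cc2cccc(F)c2)cc1-c1ccccc1`, differs from compound 3 in one place: fluoro in place of cyano on an aromatic carbon. The measured steps that might inform this change are a step that the two limits leave unreadable from compound 1 to compound 3 and a step that the two limits leave unreadable from compound 2 to compound 3, together with a step that the two limits leave unreadable from compound 1 to compound 2; each of them runs between two limits, so none has a readable size or direction. Three substituents of different character on the same aromatic carbon have left this assay at its limit every time.

Compound 4 is expected to behave the same way, with an estimate of 15000 nM and a range from 5000 nM to 50000 nM, most likely reported as a limit once more. The expected step is a step that the limit leaves unreadable from compound 3 to compound 4, that is, none beyond the scatter.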

Compound 4, half-maximal effective concentration: > 1000 nM
Compound 4 gave a limit, no number (the forecaster's own chance of this, stated with the estimate: 85%); the middle value lies beyond the limit too.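

For the compounds shown here, no step from compound 1, compound 2 or compound 3 to compound 4 can be read, as all four values are limits and not numbers. The compounds shown leave open the amount at which any of them would produce an effect in this assay, and whether methyl, chloro, cyano and fluoro differ there at all.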